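The source may report more compounds than this note shows. Statements on the series, on what has been measured and on what is new or still open speak of the compounds shown alone.

Among the measured compounds shown here, compound 2 `CCCCCCCN(CCCCCSc1nc(N)c2c[nH]nc2n1)C(=O)Nc1ccc(F)cc1F` holds the higher of the two numbers measured so far: in an assay on cells (Macrophage) for inhibition of sterol O-acyltransferase 1 (Mus musculus) (on this read-out lower numbers stand for stronger inhibition and higher numbers for weaker inhibition), compound 2 gives 72500 nM, whereas compound 1 `CCCCCCCN(CCCCCSc1nc(O)c2ccccc2n1)C(=O)Nc1ccc(F)cc1F` gives 11000 nM. For the measured compounds named here, the only measured step in the set is an exchange of the bicyclic group on the sulfur, and it runs a 6.6-fold higher number from compound 1 to compound 2 (0.82 log units; beyond the scatter). Compound 3 `CCCCCCCN(CCCCCSc1[nH]cnc2nncc1-2)C(=O)Nc1ccc(F)cc1F` is the next member of the series and has not yet been measured. It differs from compound 2 in a group of 9 heavy atoms (5 carbon, 4 nitrogen; one five-membered aromatic ring with 2 hetero atoms, one six-membered aromatic ring with 2 hetero atoms) in place of a group of 10 heavy atoms (5 carbon, 5 nitrogen; one five-membered aromatic ring with 2 hetero atoms, one six-membered aromatic ring with 2 hetero atoms), on a sulfur; the rest of the molecule is kept unchanged. The step from compound 1 to compound 2 is the only one that bears on this change, as it too exchanges the whole bicyclic group on the sulfur, and it was modest in size. Going by the values given here, no measured pair isolates the present exchange, so there is no ground for a large shift in either direction in this assay. The expected step is a 1.5-fold lower number from compound 2 to compound 3 (0.16 log units; within the scatter), which is judged to lie within the scatter. Compound 3 is estimated at 50000 nM, with a range from 15000 nM to 160000 nM.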

Compound 3, half-maximal inhibitory concentration: 3310 nM
For compound 3 the middle estimate is 15-fold (1.18 log units) above the measured one, and the stated range ends above it.
By their numbers in this assay, from the lowest: compound 3; then compound 1; then compound 2.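

In this assay, the group on the sulfur proves able to move the number far more than the first exchange suggested, with a 22-fold lower number from compound 2 to compound 3 (1.34 log units; beyond the scatter). The exchange from the group of compound 1 gives a 3.3-fold lower number from compound 1 to compound 3 (0.52 log units; beyond the scatter), so compound 1 falls between the other two even though compound 2 and compound 3 both carry one five-membered aromatic ring with 2 hetero atoms and one six-membered aromatic ring with 2 hetero atoms; among these three compounds, this ring description alone therefore does not settle the number. Nothing measured here gives a reason for these differences.

The groups of compound 2 and compound 3 differ as whole units, so the shown compounds cannot say which feature of the exchange carries the large step. As far as these compounds go, it also remains open whether a methyl group or a chlorine atom on the group of compound 3 would keep its number in this range, and whether the result would hold with a chain shorter or longer than the seven-carbon chain on the urea nitrogen.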